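The source may report more compounds than this note shows. Statements on the series, on what has been measured and on what is new or still open speak of the compounds shown alone.

Compound 1 `c1ccc(CNC(c2ccc[nH]2)c2nnc(-c3ccccc3)o2)cc1`: 231000 nM
Compound 2 `COc1ccccc1CNC(c1ccc[nH]1)c1nnc(-c2ccccc2)o1`: 279000 nM

Both compounds were tested in a functional assay on HT-1080 cells (Homo sapiens) for cytotoxicity, read by MTT assay, with a stated time of 24 h; a higher number here means a weaker inhibitor, a lower number a stronger inhibitor. For the measured compounds named here, compound 2 holds the higher of the two numbers, but its only neighbour is compound 1, and the step of a 1.2-fold higher number from compound 1 to compound 2 (0.08 log units; within the scatter) lies within the scatter, so the two cannot be told apart on these data. Compound 3 `COc1ccc(CNC(c2ccc[nH]2)c2nnc(-c3ccccc3)o2)cc1` has not yet been measured. It differs from compound 2 in one respect: 4-methoxyphenyl in place of 2-methoxyphenyl on a saturated chain carbon bound to an amine nitrogen. Going by the values given here, no measured step moves a methoxy group from one place on the ring to another. Among the compounds with values here, the single step on record, a 1.2-fold higher number from compound 1 to compound 2 (0.08 log units; within the scatter), concerns adding a methoxy group to compound 1 and left the number essentially where it was. Nothing here therefore points to a shift beyond the scatter in this assay, in either direction, when the methoxy group is moved. The step of a 1.1-fold lower number from compound 2 to compound 3 (0.03 log units; within the scatter) is accordingly expected to be small. Compound 3 is estimated to give 260000 nM, with a range from 120000 nM to 560000 nM.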

Compound 3, half-maximal inhibitory concentration: 175000 nM
The estimate for compound 3 lay 1.5-fold (0.17 log units) above the measured number; the range from low to high includes it.
By their numbers in this assay, from the lowest: compounds 3, 1 and 2 (each within the scatter of the next).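

In this assay, for the compounds shown here, the methoxy group has now been moved on the ring, which the earlier compounds did not show, and the step of a 1.6-fold lower number from compound 2 to compound 3 (0.20 log units; within the scatter) lies within the scatter, so 2-methoxyphenyl and 4-methoxyphenyl cannot be told apart at this place, on a saturated chain carbon bound to an amine nitrogen. The ring without a methoxy group also stays level with the new compound, since the step of a 1.3-fold lower number from compound 1 to compound 3 (0.12 log units; within the scatter) lies within the scatter as well, and so neither of the two methoxy placements shown separates from compound 1 in this cell assay. No measured information on these compounds beyond these numbers bears on the result.

The three compounds shown cover only hydrogen and methoxy on this ring, so it remains open whether a quite different group there, such as an amine, a carboxylic acid or a longer chain, would move the number beyond the scatter. They also leave open whether a change elsewhere in the shared core would matter more than any change on this ring.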